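Benzyl carbamate series: from compound 2 to compound 3

The source may hold more compounds than are shown below. What is called first, only, known or untested is meant among the compounds shown, and "the series" means these compounds.

In a functional assay on MCF7 cells (Homo sapiens) for inhibition, read by MTT assay, with a stated time of 72 h (on this read-out lower numbers stand for stronger inhibition and higher numbers for weaker inhibition), compound 1 (`CCc1nc2c(C)cc(-c3ccc(CN4CCN(C)CC4)cc3)cn2c1NC(=O)OCc1cc(Cl)cc(Cl)c1`) gives 5780 nM.

Compound 2 (`CCc1nc2c(C)cc(-c3ccc(CN4CCN(C)CC4)cc3)cn2c1NC(=O)OCc1ccc(C(F)(F)F)cc1`) gives > 20000 nM, which is a limit of this assay and not a number. Its place in the series is the limit of > 20000 nM in this assay, at which 1 of the 2 values shown sits.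

Compound 3 (`CCc1nc2c(C)cc(-c3ccc(CN4CCN(C)CC4)cc3)cn2c1NC(=O)OCc1ccc(F)c(F)c1`) follows from compound 2 by this change: 3,4-difluorophenyl in place of 4-(trifluoromethyl)phenyl on a saturated chain carbon bound to an oxygen next to a carbonyl group. It puts 3,4-difluorophenyl in place of 4-(trifluoromethyl)phenyl on a saturated chain carbon bound to an oxygen next to a carbonyl group.

Going by the values given here, the one measured step at this place is an at least 3.4-fold higher number from compound 1 to compound 2 (0.53 log units; beyond the scatter), beyond the scatter and open-ended. With a single step, the expectation is weakly grounded and leans on compound 1 at 5780 nM.

A modest move to a lower number is expected, stated as an at least 2.0-fold lower number from compound 2 to compound 3 (0.30 log units; that floor lies within the scatter).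

For compound 3 the estimate is 10000 nM, with an expected range of 4000 nM to 25000 nM.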

Compound 3, half-maximal inhibitory concentration: 6440 nM
Compound 3: middle estimate off by 1.6-fold (0.19 log units), on the high side; measured number inside the range.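

On the saturated chain carbon bound to an oxygen next to a carbonyl group, the 3,4-difluorophenyl group gives a measurable number in this assay, with an at least 3.1-fold lower number from compound 2 to compound 3 (0.49 log units; beyond the scatter). Against 3,5-dichlorophenyl, the same group gives a 1.1-fold higher number from compound 1 to compound 3 (0.05 log units; within the scatter), so these two groups cannot be told apart here, and 4-(trifluoromethyl)phenyl is the one of the three that stands apart. Compound 2 holds a limit of the assay and not a number, so its gap to the other two stays open-ended: the limit of > 20000 nM in this assay, at which 1 of the 3 values shown sits.

Going by these compounds, whether the substituents on this ring matter at all stays open, and an unsubstituted phenyl or a pyridine ring at this place would test that. On these data alone, the shared carbamate link also stays open, and how a urea in its place would read in this assay is unknown.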